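Swapping the aryl ketone in a pyrazolopyrimidine chalcone series

The compounds below may be only part of what the source reports. "The series", "measured", "known", "first", "only" and "open" are said of these compounds alone.

Three compounds in this group have been characterised in a functional assay on MDA-MB-231 cells (Homo sapiens) for antiproliferative activity, read by MTT assay, with a stated time of 24 h; a higher number here means a weaker inhibitor, a lower number a stronger inhibitor. Compound 1 `COc1ccc(/C=C/C(=O)c2cc(-c3ccc(OC)c(OC)c3)n3nc(-c4ccccc4)cc3n2)cc1` gives 22000 nM. Compound 2 `COc1ccc(-c2cc(/C=C/C(=O)c3ccc(C)cc3)nc3cc(-c4ccccc4)nn23)cc1OC` gives 19800 nM. Compound 3 `COc1cc(-c2cc(/C=C/C(=O)c3ccc(C)cc3)nc3cc(-c4ccccc4)nn23)cc(OC)c1OC` gives 23900 nM. Compound 2 therefore stands with its two neighbours close at hand: the gaps to compound 1 and to compound 3 both lie within the scatter, so the three are indistinguishable on these numbers.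

Compound 4 `COc1ccc(C(=O)/C=C/c2cc(-c3ccc(OC)c(OC)c3)n3nc(-c4ccccc4)cc3n2)cc1OC` has not been measured in this assay. It differs from compound 2 in one place: 3,4-dimethoxyphenyl in place of 4-methylphenyl on a carbonyl carbon. Within the data shown here, two measured steps bear on this. The step of a 1.1-fold lower number from compound 1 to compound 2 (0.05 log units; within the scatter) shows that rearranging the enone-linked aryl groups left the number within the scatter. The step of a 1.2-fold higher number from compound 2 to compound 3 (0.08 log units; within the scatter) shows that adding a methoxy group on an aromatic carbon likewise left the number within the scatter. Nothing in the data points to an exchange of the aryl group on the carbonyl carbon producing a step beyond the scatter in this assay.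

Compound 4 is accordingly expected to give about 20000 nM, within a range from 9000 nM to 45000 nM. The expected step of a 1.0-fold higher number from compound 2 to compound 4 (0.00 log units; within the scatter) is estimated to lie within the scatter.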

Compound 4, half-maximal inhibitory concentration: 2600 nM
The estimate for compound 4 lay 7.7-fold (0.89 log units) above the measured number, outside the stated range (below it).
By their numbers in this assay, from the lowest: compound 4; then compounds 2, 1 and 3 (each within the scatter of the next).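

In this assay the aryl group on the carbonyl carbon proves to be a place where one exchange moves the number beyond the scatter: 3,4-dimethoxyphenyl in place of 4-methylphenyl gives a 7.6-fold lower number from compound 2 to compound 4 (0.88 log units; beyond the scatter) and sets compound 4 apart from the other three compounds. Among these compounds, the two earlier steps both stayed within the scatter, so they gave no sign that this group mattered, and this is the first change in the set to separate one compound from the others. Nothing measured here accounts for the drop in the number.

The compounds shown leave open whether both methoxy groups are needed, since no compound carries a single methoxy group on this aryl ring, and whether other groups there, such as a hydroxy group, an amine or a carboxylic acid, would take the number lower still or lose the gain. They also leave open whether the same exchange would hold with the other aryl group on the core changed, for instance to the 3,4,5-trimethoxyphenyl of compound 3.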